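The source may report more compounds than this note shows. Statements on the series, on what has been measured and on what is new or still open speak of the compounds shown alone.

Working notes on the anilide ester series built on the shared core of compound 1 `O=C(CCC(=O)OCCCCCCSc1ccc([N+](=O)[O-])c2nonc12)Nc1cccc(Cl)c1`. In a functional assay on 143B cells (Homo sapiens) for inhibition, read by MTT assay, with a stated time of 72 h (a higher number here means a weaker inhibitor, a lower number a stronger inhibitor), compound 1 gives 2890 nM. Compound 2 `O=C(CCC(=O)OCCCCCCSc1ccc([N+](=O)[O-])c2nonc12)Nc1ccc(Br)cc1` gives 2710 nM in this assay, and compound 3 `Cc1ccc(NC(=O)CCC(=O)OCCCCCCSc2ccc([N+](=O)[O-])c3nonc23)cc1` gives 3250 nM in this assay. Compound 3 returns the highest of the three numbers, yet compound 1, its nearest neighbour, and compound 2, its furthest, both sit within the scatter of it, so no ranking among the three is drawn.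

The single-point steps read: a 1.1-fold lower number from compound 1 to compound 2 (0.03 log units; within the scatter); a 1.1-fold higher number from compound 1 to compound 3 (0.05 log units; within the scatter); a 1.2-fold higher number from compound 2 to compound 3 (0.08 log units; within the scatter). Every exchange of the aryl group on the amide-type nitrogen so far has left the number where it was.

The next compound, compound 4 `COc1ccc(NC(=O)CCC(=O)OCCCCCCSc2ccc([N+](=O)[O-])c3nonc23)cc1OC`, differs from compound 3 by 3,4-dimethoxyphenyl in place of 4-methylphenyl on an amide-type nitrogen. Among the measured compounds shown here, no measured step introduces two oxygen-bearing substituents on that ring, so the bearing steps are the three aryl swaps above, each within the scatter. On that basis no step beyond the scatter is expected in this assay, and a 1.1-fold lower number from compound 3 to compound 4 (0.03 log units; within the scatter) is the expected outcome. Compound 4 is therefore estimated at 3000 nM, with a range from 1500 nM to 6500 nM.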

Compound 4, half-maximal inhibitory concentration: 2770 nM
For compound 4 the middle estimate is 1.1-fold (0.03 log units) above the measured one, within the range that was stated.
By their numbers in this assay, from the lowest: compounds 2, 4, 1 and 3 (each within the scatter of the next).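

Working from this assay, the 3,4-dimethoxyphenyl group on the amide-type nitrogen extends the flat picture at this position, with a 1.2-fold lower number from compound 3 to compound 4 (0.07 log units; within the scatter) and a 1.0-fold higher number from compound 2 to compound 4 (0.01 log units; within the scatter) and also a 1.0-fold lower number from compound 1 to compound 4 (0.02 log units; within the scatter) as the three readings. Among the compounds shown here, the earlier aryl swaps exchanged only one small substituent for another, whereas this change takes the group from 7 to 10 heavy atoms and from 0 to 2 hydrogen-bond acceptors, and still no step leaves the scatter, so across these four compounds the number does not follow the size of the aryl group or its acceptor count. No supporting measurement accompanies these numbers to show what sets them.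

All four aryl groups shown are phenyl rings carrying halogen, methyl or methoxy substituents, so it remains open whether a carboxylic acid or a dimethylamino group on that ring, or a pyridine in its place, would produce a step beyond the scatter. Also open, going by these compounds, is how much the number depends on the anilide at all, since an unsubstituted amide or a longer chain in place of the aryl group falls outside this set.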